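Halogen swap on a thiazolidinone series: what compound 4 may give

A few compounds are considered here, and "the series" means these few. Any claim that something is new, unique, unknown or untested is made for them only; others in the source may bear on it.

Measured so far:
Compound 1, `O=C1NC(=S)/C(=C/c2ccc(Br)cc2)S1`, gives 16.6% in a functional assay on NCI-H292 cells (Homo sapiens) for cytotoxicity, read by MTT assay, with a stated time of 72 h, tested at 5 ug/mL; on this read-out higher numbers stand for more inhibition of growth at the one concentration tested and lower numbers for less inhibition of growth.
Compound 2, `O=C1NC(=S)/C(=C/c2cccc(F)c2)S1`, gives 13.1% in this assay.
Compound 3, `O=C1NC(=S)/C(=C/c2ccc(F)cc2)S1`, gives 31.6% in this assay.

Compound 3 stands highest of the three. Compound 2 and compound 1 lie within the scatter of each other, so no order between them can be read. Compound 3 and compound 2 have the same atoms joined differently, and the difference between the two cores is not broken down here.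

One change has been measured once: bromo in place of fluoro on an aromatic carbon, where the place is para to a group of 8 heavy atoms. This gave a number 15 percentage points lower from compound 3 to compound 1 (beyond the scatter).

Compound 4, `O=C1NC(=S)/C(=C/c2cccc(Br)c2)S1`, is not yet measured. It arises from compound 2 by bromo in place of fluoro on an aromatic carbon, with the place meta to a group of 8 heavy atoms. This is the same kind of change, not the same change. If it behaves like the earlier step, the expected step is a number 6.1 percentage points lower from compound 2 to compound 4 (within the scatter), resting on a number 15 percentage points lower from compound 3 to compound 1 (beyond the scatter) applied to compound 2 at 13.1%. Compound 4 is therefore expected to give about 7%, estimated to fall between 0% and 22%.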

Compound 4, percent growth inhibition at one concentration: 22%
Beside the measured number, compound 4's estimate is 15 percentage points below it, and the stated range covers the measured number.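

In this assay, the new step, bromo in place of fluoro, is a number 8.9 percentage points higher from compound 2 to compound 4 (within the scatter), so no order can be read between these two compounds. Set beside the earlier step, the same swap does not give the same result on the two cores: the same change on two cores in this assay, a number 15 percentage points lower (beyond the scatter) from compound 3 to compound 1 and a number 8.9 percentage points higher (within the scatter) from compound 2 to compound 4, 23.9 percentage points apart, beyond the scatter of two such steps

This shows that the step measured on one core could not be carried over as a fixed number to the other core in this series. Among the compounds shown here, it does not show why the two steps part, and with only two pairs it gives no rule for what the swap would do on any further core.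

The compounds shown carry only fluoro or bromo as the changing group, so they leave open how a chloro group, a methoxy group, an amine or a carboxylic acid in the same places would read. They also leave open whether the gap between the two steps would hold at other test concentrations.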